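Styryl sulfone series: from compound 3 to compound 4

This account rests on a few compounds, and the source may have more. Where it says the series, first, only, none or still open, it means among the compounds named here.

compound 1 `COc1ccc(/C=C(\C(=O)c2ccc(Br)cc2)S(=O)(=O)c2ccc(Br)cc2)cc1` gives 25000 nM
compound 2 `Cc1ccc(CS(=O)(=O)/C(=C/c2cc(C)cc(C)c2)C(=O)c2ccc(Cl)cc2)cc1` gives 10000 nM
compound 3 `COc1ccc(/C=C(\C(=O)c2ccc(Br)cc2)S(=O)(=O)c2ccc(Br)cc2)c(F)c1` gives 10000 nM

All three numbers come from a functional assay on DU-145 cells (Homo sapiens) for inhibition, read by trypan blue exclusion, with a stated time of 96 h (a higher number here means a weaker inhibitor of growth, a lower number a stronger inhibitor of growth), and they set the frame for the next compound. Compound 3 is level with compound 2 at the digits given, and these two share the lowest number of the three. Compound 1 carries the highest number.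

The next compound is compound 4 `O=C(/C(=C\c1ccc(I)cc1)S(=O)(=O)c1ccc(Br)cc1)c1ccc(Br)cc1` and the change is 4-iodophenyl in place of 2-fluoro-4-methoxyphenyl on a double-bonded chain carbon bound to a double-bonded chain carbon in which 4-iodophenyl stands in place of 2-fluoro-4-methoxyphenyl on a double-bonded chain carbon bound to a double-bonded chain carbon.

Among the measured compounds shown here, one measured step bears on this: a 2.5-fold lower number from compound 1 to compound 3 (0.40 log units; beyond the scatter) for fluoro in place of hydrogen on an aromatic carbon. Compound 4 loses that fluoro, so part of that modest gain may be given back. Compound 2 differs in too many places to offer a comparable step. For the measured compounds named here, no measured step shows what iodine does on this ring, so the direction rests on the fluoro alone and stays uncertain.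

The expected change in this assay is a 1.5-fold higher number from compound 3 to compound 4 (0.18 log units; within the scatter) and a small move toward a higher number is all that is anticipated. The estimate for compound 4 is 15000 nM with a range of 5000 nM to 40000 nM as the expected span.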

Compound 4, concentration for 50% growth inhibition: 1000 nM
Compound 4: the middle estimate sits 15-fold (1.18 log units) above what was measured; measured number below the stated range.
By their numbers in this assay, from the lowest: compound 4; then compounds 2 and 3 (each within the scatter of the next); then compound 1.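

In this assay, the step to 4-iodophenyl on a double-bonded chain carbon bound to a double-bonded chain carbon, a 10-fold lower number from compound 3 to compound 4 (1.00 log units; beyond the scatter), shows that the fluoro is not needed for a low number at this position: compound 4 has no fluoro yet gives the lowest number of the four compounds. The single change of iodo in place of methoxy, a 25-fold lower number from compound 1 to compound 4 (1.40 log units; beyond the scatter), is the first large step in the series and points to the group at this spot on the ring, rather than the fluoro, as the main handle among the compounds shown. No supporting data accompany these steps that would explain either of them, so the result stands as an observation only.

On these data alone, it remains open whether a fluoro added to the 4-iodophenyl ring would lower the number further than compound 4 at 1000 nM, or whether the two changes do not add up. Also open, as far as these compounds go, is how narrowly the result depends on iodo, since a chloro, an amine or a carboxylic acid in its place would test whether other groups hold the same level.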